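The source may hold more compounds than are shown below. What is called first, only, known or untested is meant among the compounds shown, and "the series" means these compounds.

Of the compounds shown here, two built on one shared core have been tested in an ADME assay on HepG2 cells (Homo sapiens) for cytotoxicity, with a stated time of 72 h; on this read-out higher numbers stand for an effect only at larger amounts of compound and lower numbers for an effect already at smaller amounts. Compound 1 `COc1ccc(NC(=O)Nc2cc(C)nc3ccccc23)cc1` carries a methoxy group on an outer aromatic ring. In this assay compound 1 gives > 25000 nM, which is a limit of the assay rather than a number. Compound 2 `Cc1cc(NC(=O)Nc2ccc(N)cc2)c2ccccc2n1` differs from compound 1 by amino in place of methoxy on an aromatic carbon. In this assay compound 2 gives > 25000 nM, again a limit and not a number. The step that the two limits leave unreadable from compound 1 to compound 2 cannot be read because both values sit at the limit of > 25000 nM in this assay, at which 2 of the 2 values shown sit.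

Compound 3 `Cc1cc(NC(=O)Nc2ccc(F)cc2)c2ccccc2n1` has not yet been measured. It differs from compound 2 by fluoro in place of amino on an aromatic carbon. Among the compounds with values here, the only measured step is unreadable, and neither measured value points in any direction; so nothing here argues that compound 3 should behave differently from compound 2. For compound 3 the expected step that the limit leaves unreadable from compound 2 to compound 3 is therefore none beyond the scatter. For compound 3 the estimate is 30000 nM, with a range from 10000 nM to 100000 nM, and the result will most likely again be reported only as a limit.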

Compound 3, half-maximal effective concentration: > 25000 nM
Compound 3: a limit, no number; the forecaster's own chance of this, stated with the estimate: 85%; the middle value is on the limit's open side.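

Within the data shown here, no step to compound 3 can be read from compound 1 or compound 2, because all three compounds sit at the same limit rather than at a number: the limit of > 25000 nM in this assay, at which 3 of the 3 values shown sit. The compounds shown leave open what amount of each compound, if any, would give an effect in this assay, and whether methoxy, amino and fluoro differ at all.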